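Phenyl in Place of Octyl on the Aromatic Nitrogen

A few compounds are considered here, and "the series" means these few. Any claim that something is new, unique, unknown or untested is made for them only; others in the source may bear on it.

Measured compounds in a functional assay on HeLa cells (Homo sapiens) for inhibition, read by MTT assay, with a stated time of 24 h; a lower number here means a stronger inhibitor, a higher number a weaker inhibitor:
compound 1 `CCOC(=O)C1=Cc2ccccc2OC1(OCc1cn(-c2cccc(OC)c2)nn1)C(F)(F)F`: > 150000 nM, a limit of this assay
compound 2 `CCOC(=O)C1=Cc2ccccc2OC1(OCc1cn(CC(=O)NC2CCCCC2)nn1)C(F)(F)F`: 11400 nM
compound 3 `CCCCCCCCn1cc(COC2(C(F)(F)F)Oc3ccccc3C=C2C(=O)OCC)nn1`: > 150000 nM, a limit of this assay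

Compound 3 sits at the limit of > 150000 nM in this assay, at which 2 of the 3 values shown sit, so no number is known for it. Compound 4 `CCOC(=O)C1=Cc2ccccc2OC1(OCc1cn(-c2ccccc2)nn1)C(F)(F)F` differs from it by phenyl in place of octyl on an aromatic nitrogen. Among the measured compounds shown here, two measured steps bear on this change. The step that the two limits leave unreadable from compound 1 to compound 3 swaps an aryl group for the octyl chain, yet both ends are limits, so its size stays unreadable. The step of an at least 13-fold higher number from compound 2 to compound 3 (1.11 log units; beyond the scatter) shows the octyl compound far weaker than compound 2. Compound 1 carries 3-methoxyphenyl, close to the phenyl entering in compound 4, and sits at the limit. Compound 4 is therefore expected to stay at or near the limit. Its estimated value is 150000 nM (50000 nM to 300000 nM). The expected step is a number no higher from compound 3 to compound 4 (the limit leaves the size open).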

Compound 4, half-maximal inhibitory concentration: > 150000 nM
Compound 4 was reported as a limit; the forecaster's own chance of this, stated with the estimate: 70%; the middle value sits exactly at the limit.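

In this assay the result for compound 4 is a limit, shared with compound 1 and compound 3: the limit of > 150000 nM in this assay, at which 3 of the 4 values shown sit. The steps from compound 3 to compound 4 and from compound 1 to compound 4 cannot be read, so phenyl cannot be ranked against octyl or 3-methoxyphenyl. Phenyl in place of (cyclohexylcarbamoyl)methyl gives an at least 13-fold higher number from compound 2 to compound 4 (1.11 log units; beyond the scatter), so plain phenyl, like octyl and 3-methoxyphenyl, yields no readable number here.

Which part of the (cyclohexylcarbamoyl)methyl group matters stays open. A cyclohexyl group set directly on the aromatic nitrogen, or a primary amide on the same short chain, would help separate the two parts.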